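The source may report more compounds than this note shows. Statements on the series, on what has been measured and on what is new or still open speak of the compounds shown alone.

So far, three compounds have been measured in a functional assay on A549 cells (Homo sapiens) for cytotoxicity, read by MTT assay, with a stated time of 72 h; on this read-out higher numbers stand for weaker inhibition and lower numbers for stronger inhibition. Compound 1 (`O=C(N/N=C/c1ccc(F)cc1)Nc1cc2c(Nc3ccc(F)c(Cl)c3)ncnc2cc1O[C@H]1CCOC1`) gives 35100 nM, compound 2 (`O=C(N/N=C/c1cccc(Cl)c1Cl)Nc1cc2c(Nc3ccc(F)c(Cl)c3)ncnc2cc1O[C@H]1CCOC1`) gives 25000 nM and compound 3 (`COc1cc2ncnc(Nc3ccc(F)c(Cl)c3)c2cc1NC(=O)N/N=C/c1ccc(F)cc1`) gives 26600 nM. Compound 3 therefore stands within the usual scatter of both other compounds, and the numbers do not separate the three.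

The next compound is compound 4 (`COc1cc2ncnc(Nc3ccc(F)c(Cl)c3)c2cc1NC(=O)N/N=C/c1ccc(F)cc1Cl`), and its structure differs from compound 3 in one place: chloro in place of hydrogen on an aromatic carbon. This is chloro in place of hydrogen on an aromatic carbon, which turns 4-fluorophenyl into 2-chloro-4-fluorophenyl.

Within the data shown here, two measured steps bear on this change. The closer one alters the same phenyl group, placing 2,3-dichlorophenyl where 4-fluorophenyl stood, and it gives a 1.4-fold lower number from compound 1 to compound 2 (0.15 log units; within the scatter). The other places methyl where oxolan-3-yl stood on an oxygen and gives a 1.3-fold lower number from compound 1 to compound 3 (0.12 log units; within the scatter). Among the measured compounds shown here, both stay within the scatter, although no measured pair shows the effect of this single chloro on its own. No shift beyond the scatter is therefore expected, and the estimated change is a 1.1-fold lower number from compound 3 to compound 4 (0.03 log units; within the scatter). For compound 4 the expected value is 25000 nM, with an estimated range from 12000 nM to 50000 nM.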

Compound 4, half-maximal inhibitory concentration: 28200 nM
The estimate for compound 4 lay 1.1-fold (0.05 log units) below the measured number, and the stated range covers the measured number.
By their numbers in this assay, from the lowest: compounds 2, 3, 4 and 1 (each within the scatter of the next).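

Compound 3 and compound 4 form the first pair shown in which a single chloro is the only difference, with the 4-fluorophenyl group becoming 2-chloro-4-fluorophenyl. In this assay, this gives a 1.1-fold higher number from compound 3 to compound 4 (0.03 log units; within the scatter), so on this aromatic carbon, ortho to a large group and meta to the fluoro group, one added chlorine does not separate the two compounds. The earlier step within this phenyl group altered more than one position at once, whereas this pair keeps the fluoro group in place and isolates the chloro, although no measurement shown offers an explanation for the result.

The compounds shown leave open whether a different group on this same carbon, such as an amine, a carboxylic acid or a longer chain, would move the number beyond the scatter. They also leave open whether the same chloro would give a similar result with oxolan-3-yl rather than methyl on the oxygen of the shared core.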